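The compounds below may be only part of what the source reports. "The series", "measured", "known", "first", "only" and "open" are said of these compounds alone.

Compound 1, `O=C1C=C(N2CCC2)C(=O)c2c1nc1n2[C@H]2OC[C@@H](O)[C@H]2OC1`, is tested in a functional assay on MGC-803 cells (Homo sapiens) for inhibition, read by sulforhodamine B assay; a lower number here means a stronger inhibitor, a higher number a weaker inhibitor. In this assay compound 1 gives > 16000 nM, which is a limit of the assay rather than a number. Compound 2, `O=C1C(NC2CCCC2)=CC(=O)c2c1nc1n2[C@H]2OC[C@@H](O)[C@H]2OC1`, also gives only > 16000 nM, a limit. Compound 3, `COc1ccc(NC2=CC(=O)c3c(nc4n3[C@H]3OC[C@@H](O)[C@H]3OC4)C2=O)cc1`, gives 2150 nM. The step of an at least 7.4-fold lower number from compound 2 to compound 3 (0.87 log units; beyond the scatter) is the only measured one, and compound 1 shares the limit of > 16000 nM in this assay, at which 2 of the 3 values shown sit, with compound 2.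

Compound 4, `COc1ccc(NC2=CC(=O)c3nc4n(c3C2=O)[C@H]2OC[C@@H](O)[C@H]2OC4)cc1`, differs from compound 1 by (4-methoxyphenyl)amino in place of azetidin-1-yl on a double-bonded ring carbon. The change resembles the step from compound 2 to compound 3, which was at least modest, so a drop of similar size is expected here, an at least 5.3-fold lower number from compound 1 to compound 4 (0.72 log units; beyond the scatter). Compound 4 is therefore estimated at 3000 nM in this assay, between 900 nM and 12000 nM.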

Compound 4, half-maximal inhibitory concentration: 1680 nM
Beside the measured number, compound 4's estimate is 1.8-fold (0.25 log units) above it; the measured number falls inside the stated range.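

On this double-bonded ring carbon, (4-methoxyphenyl)amino in place of azetidin-1-yl gives an at least 9.5-fold lower number from compound 1 to compound 4 (0.97 log units; beyond the scatter) in this assay and so shows that the gain is not tied to replacing a cyclopentyl group. The full size of this step cannot be read, as it starts from a limit: the limit of > 16000 nM in this assay, at which 2 of the 4 values shown sit.

Still open, from the compounds shown here alone, is whether the methoxy group is needed, since a plain phenyl or a 4-chlorophenyl on the same amine nitrogen would test that. A benzyl group there would show whether the ring must sit directly on that nitrogen.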